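Moving the Trifluoromethyl Group on the Urea Aryl Ring

The source may report more compounds than this note shows. Statements on the series, on what has been measured and on what is new or still open speak of the compounds shown alone.

Compound 1 `CN(C)CCn1cnnc1-c1cc(Oc2ccc(NC(=O)Nc3ccc(Cl)c(C(F)(F)F)c3)cc2F)ccn1`: 1070 nM
Compound 2 `CN(C)CCn1cnnc1-c1cc(Oc2ccc(NC(=O)Nc3cccc(C(F)(F)F)c3)cc2F)ccn1`: 16400 nM

In a functional assay on MDA-MB-231 cells (Homo sapiens) for antiproliferative activity, read by MTT assay, with a stated time of 72 h (on this read-out higher numbers stand for weaker inhibition and lower numbers for stronger inhibition), compound 2 stands at the higher of the two numbers measured, since the step of a 15-fold higher number from compound 1 to compound 2 (1.19 log units; beyond the scatter) lies beyond the scatter. Compound 3 `CN(C)CCn1cnnc1-c1cc(Oc2ccc(NC(=O)Nc3ccccc3C(F)(F)F)cc2F)ccn1` differs from compound 2 by 2-(trifluoromethyl)phenyl in place of 3-(trifluoromethyl)phenyl on an amide-type nitrogen. Among the compounds with values here, no measured step moves a group from one ring position to another; the only step in hand concerns a chloro group and does not bear directly on this change. The step is therefore expected to be a 1.8-fold higher number from compound 2 to compound 3 (0.26 log units; within the scatter), which may well remain within the scatter. Compound 3 is estimated at 30000 nM, with a range from 8000 nM to 100000 nM.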

Compound 3, half-maximal inhibitory concentration: > 50000 nM
Compound 3: a limit, no number; the forecaster's own chance of this, stated with the estimate: 25%; middle value at least 1.6-fold (0.22 log units) away from the limit.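

In this assay, the value of compound 3 is a limit of the assay and not a number: the limit of > 50000 nM in this assay, at which 1 of the 3 values shown sits.

Placing 2-(trifluoromethyl)phenyl in place of 3-(trifluoromethyl)phenyl on the amide-type nitrogen gives an at least 3.0-fold higher number from compound 2 to compound 3 (0.48 log units; beyond the scatter), so the same atoms, joined differently, shift the read-out beyond the scatter. Putting 2-(trifluoromethyl)phenyl in place of 4-chloro-3-(trifluoromethyl)phenyl gives an at least 46-fold higher number from compound 1 to compound 3 (1.66 log units; beyond the scatter).

On these data alone, how far the number of compound 3 lies past the limit remains open. As far as these compounds go, it is also open how a methoxy group or an amine in place of trifluoromethyl on this ring would read.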